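Chloro for Methoxy on the Thiourea Aryl Ring

The compounds below may be only part of what the source reports. "The series", "measured", "known", "first", "only" and "open" are said of these compounds alone.

Compounds measured so far:
Compound 1 `COc1cccc(NC(=S)NC2CC(C)(C)Oc3ccc(Br)cc32)c1`: in a functional assay on B16-F10 cells (Mus musculus) for inhibition, read by MTT assay, with a stated time of 72 h (on this read-out higher numbers stand for weaker inhibition and lower numbers for stronger inhibition), compound 1 gives "not determined" (no result reported), no result reported.
Compound 2 `CC1(C)CC(NC(=S)Nc2cccc(Cl)c2)c2cc(Br)ccc2O1`: compound 2 gives 7000 nM in this assay.
Compound 3 `COc1ccccc1NC(=S)NC1CC(C)(C)Oc2ccc(Br)cc21`: compound 3 gives "not determined" (no result reported) in this assay, no result reported.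

Compound 3 stands without a number; among the measured compounds only compound 2 carries a value, and compound 1 shares with compound 3 the absence of a result. Compound 4 `CC1(C)CC(NC(=S)Nc2ccccc2Cl)c2cc(Br)ccc2O1` differs from compound 3 by chloro in place of methoxy on an aromatic carbon. For the measured compounds named here, since compound 3 has no value, the step cannot be sized against it, and the only anchor is compound 2, which also carries a chloro group on its aryl ring. In this assay a shift beyond the scatter in either direction is possible, but none is required. Compound 4 is expected to give about 7000 nM, in a range from 2000 nM to 25000 nM.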

Compound 4, half-maximal inhibitory concentration: 17000 nM
Compound 4: middle estimate off by 2.4-fold (0.39 log units), on the low side; measured number inside the range.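

For the compounds shown here, compound 4 gives the first comparison at this ring: in this assay, 2-chlorophenyl in place of 3-chlorophenyl gives a 2.4-fold higher number from compound 2 to compound 4 (0.39 log units; beyond the scatter), so with the same group on the same ring, its place alone moves the result beyond the scatter, towards weaker inhibition. The change from methoxy to chloro itself cannot be read: compound 3 carries no number. Nothing measured here explains the shift.

Open, as far as these compounds go, is how methoxy compares with chloro on this ring in either place, and whether a fluoro group, an amine or a carboxylic acid there would follow the chloro pair.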